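This account rests on a few compounds, and the source may have more. Where it says the series, first, only, none or still open, it means among the compounds named here.

Compound 1 `COc1cccc(/C=C/C(=O)Nc2cc(OC)c(OC)c(OC)c2)c1` gives 2400 nM in a functional assay on HT-29 cells (Homo sapiens) for cytotoxicity, read by MTT assay, with a stated time of 72 h; a higher number here means a weaker inhibitor, a lower number a stronger inhibitor.
Compound 2 `COc1ccc(C(=O)c2cc(OC)c(OC)c(OC)c2)cc1NC(=O)/C=C/c1ccc(OC)c(OC)c1` gives 2500 nM.
Compound 3 `C#CCOc1cccc(/C=C/C(=O)Nc2cc(C(=O)c3cc(OC)c(OC)c(OC)c3)ccc2OC)c1` gives 7400 nM.

Compound 3 stands at the highest number of the three, with compound 2 nearest and compound 1 furthest, both lower by steps beyond the scatter. Compound 4 `COc1cc(/C=C/C(=O)Nc2cc(C(=O)c3cc(OC)c(OC)c(OC)c3)ccc2OC)ccc1F` differs from compound 3 by 4-fluoro-3-methoxyphenyl in place of 3-(propargyloxy)phenyl on a double-bonded chain carbon bound to a double-bonded chain carbon. For the measured compounds named here, the only measured step bearing on this position is a 3.0-fold higher number from compound 2 to compound 3 (0.47 log units; beyond the scatter), in which 3-(propargyloxy)phenyl replaced 3,4-dimethoxyphenyl. The 4-fluoro-3-methoxyphenyl of compound 4 shares a methoxy group with the 3,4-dimethoxyphenyl of compound 2, so a partial reversal of that step, toward a lower number in this assay, is expected. Compound 4 is therefore estimated at 3500 nM (range 1500 nM to 9000 nM), an expected 2.1-fold lower number from compound 3 to compound 4 (0.33 log units; beyond the scatter).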

Compound 4, half-maximal inhibitory concentration: 7700 nM
The estimate for compound 4 lay 2.2-fold (0.34 log units) below the measured number; the range from low to high includes it.
By their numbers in this assay, from the lowest: compounds 1 and 2 (each within the scatter of the next); then compounds 3 and 4 (each within the scatter of the next).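

In this assay, the move to 4-fluoro-3-methoxyphenyl gives a 1.0-fold higher number from compound 3 to compound 4 (0.02 log units; within the scatter), so the methoxy group shared with compound 2 does not recover the lower number. Fluoro in place of methoxy on an aromatic carbon gives a 3.1-fold higher number from compound 2 to compound 4 (0.49 log units; beyond the scatter), showing that this single replacement on the 3,4-dimethoxyphenyl is enough for a step beyond the scatter. No evidence is available to explain this result. The compounds shown leave open whether a chloro or an amino group in place of that fluoro would keep the number of compound 2 or that of compound 4.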